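Chloro in place of nitro on compound 2

The source may hold more compounds than are shown below. What is called first, only, known or untested is meant among the compounds shown, and "the series" means these compounds.

In a functional assay on B16 cells (Mus musculus) for antiproliferative activity, read by MTT assay, with a stated time of 24 h (a higher number here means a weaker inhibitor, a lower number a stronger inhibitor), compound 1 `C=CCOc1ccc2c(=O)c(-c3cc(OC)c(OC)cc3OC)coc2c1` gives 5100 nM. Compound 2 `COc1cc(OC)c(-c2coc3cc(OCc4ccc([N+](=O)[O-])cc4)ccc3c2=O)cc1OC` reports only a limit of the assay, > 10000 nM. Its standing therefore rests on (the limit of > 10000 nM in this assay, at which 1 of the 2 values shown sits), and it has no number of its own.

Compound 3 `COc1cc(OC)c(-c2coc3cc(OCc4ccc(Cl)cc4)ccc3c2=O)cc1OC` keeps everything in compound 2 but one group, with chloro in place of nitro on an aromatic carbon, para to a large group (chloro in place of nitro on an aromatic carbon).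

Within the data shown here, the only measured step nearby is an at least 1.9-fold higher number from compound 1 to compound 2 (0.29 log units; that floor lies within the scatter), with 4-nitrophenyl in place of vinyl on a saturated chain carbon bound to an oxygen on an aromatic ring. Among the measured compounds shown here, that step does not exchange the nitro group, and no measured pair does. No step beyond the scatter is thus expected in this assay, and no direction can be called with confidence. For the measured compounds named here, the only firm number is compound 1 at 5100 nM, so compound 3 is expected to stay in that weak region. The expected change is an at least 1.2-fold lower number from compound 2 to compound 3 (0.09 log units; that floor lies within the scatter). For compound 3 the estimated value is 8000 nM, within an expected range of 3000 nM to 20000 nM.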

Compound 3, half-maximal inhibitory concentration: 2400 nM
The estimate for compound 3 lay 3.3-fold (0.52 log units) above the measured number; the whole stated range lies above it.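

Exchanging nitro for chloro on this aromatic carbon, para to a large group, gives a change that can be read beyond the scatter in this assay: an at least 4.1-fold lower number from compound 2 to compound 3 (0.61 log units; beyond the scatter). The position is therefore not indifferent to the group it carries, which compound 2 alone could not show. The chain end also matters, as the step with 4-chlorophenyl in place of vinyl on the saturated chain carbon is a 2.1-fold lower number from compound 1 to compound 3 (0.33 log units; beyond the scatter), so a substituted phenyl there can go with a lower number than vinyl, whereas the step to the 4-nitrophenyl group gave no such result. The value of compound 2 is a limit, so the step from it fixes only a floor and not a true size: the limit of > 10000 nM in this assay, at which 1 of the 3 values shown sits.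

On these data alone, only nitro and chloro appear on this carbon, so it remains open how fluoro, methoxy or an amine would fare there, and whether the lower number follows from chloro entering or from nitro leaving. As far as these compounds go, the exchange also rests on a single pair on one core in this assay, so whether it holds on other cores stays open as well.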